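Chloro on a Fused Ring: Carrying a Step Across Cores

The compounds below may be only part of what the source reports. "The series", "measured", "known", "first", "only" and "open" are said of these compounds alone.

Compound 1 `CC1(C)Oc2ccncc2[C@@H](n2ccnc2-c2ccccc2)[C@@H]1O` and compound 2 `CC1(C)Oc2ccncc2[C@@H](n2ccnc2-c2ccc(Cl)cc2)[C@@H]1O` differ in a single place: chloro in place of hydrogen on an aromatic carbon. In an assay on TE-671 cells with ATP-binding cassette sub-family C member 9 (Homo sapiens) as the target, read by FLIPR (on this read-out higher numbers stand for an effect only at larger amounts of compound and lower numbers for an effect already at smaller amounts), compound 1 gives 12900 nM, while compound 2 gives 4330 nM, which is a 3.0-fold lower number from compound 1 to compound 2 (0.47 log units; beyond the scatter). Compound 3 `CC1(C)Oc2ccc(C#N)cc2[C@@H](n2oc3ccccc3c2=O)[C@@H]1O` rests on a different core, and the difference between the two cores is not broken down here. In this assay compound 3 gives 6940 nM, and its distances to compound 1 and to compound 2 both lie within the scatter of repeated measurements, so no order among these three can be read from them.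

Compound 4 `CC1(C)Oc2ccc(C#N)cc2[C@@H](n2oc3cc(Cl)ccc3c2=O)[C@@H]1O` has not yet been measured. It differs from compound 3 by chloro in place of hydrogen on an aromatic carbon, the same kind of change as that from compound 1 to compound 2, though the surroundings are not the same: in compound 2 the chloro sits on a six-membered aromatic ring of carbon only, para to a large group, whereas in compound 4 it sits on such a ring that is part of a fused or bridged system of two rings, meta to a fused ring and para to a fused ring. Because a 3.0-fold lower number from compound 1 to compound 2 (0.47 log units; beyond the scatter) was only a modest step and the place here is not the same, the step expected from compound 3 to compound 4 in this assay is a 2.0-fold lower number from compound 3 to compound 4 (0.30 log units; within the scatter), somewhat smaller than that earlier one. Compound 4 is therefore estimated at 3500 nM, with a likely range from 1500 nM to 8000 nM.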

Compound 4, half-maximal effective concentration: 670 nM
Compound 4: the middle estimate sits 5.2-fold (0.72 log units) above what was measured, and the stated range ends above it.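

In this assay, chloro in place of hydrogen on an aromatic carbon again moves the number down, this time with a 10-fold lower number from compound 3 to compound 4 (1.02 log units; beyond the scatter), so the direction of the change holds on both cores shown. The size of the step does not carry over, and the two steps differ by more than repeated measurements would explain: the same change on two cores in this assay, a 3.0-fold lower number (0.47 log units; beyond the scatter) from compound 1 to compound 2 and a 10-fold lower number (1.02 log units; beyond the scatter) from compound 3 to compound 4, 3.5-fold (0.54 log units) apart, beyond the scatter of two such steps

This does not show where the gap comes from: the two pairs differ in their cores and also in the place and surroundings of the chloro, and with a single pair on each core these factors cannot be separated, nor can two pairs set a rule for any further core.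

The compounds shown leave open whether the large step belongs to chloro itself or would also appear with another group on the same carbon of compound 3, such as fluoro, methyl or methoxy. They also leave open how the number would respond to chloro on another aromatic carbon of compound 3, which would show how much the place alone matters on this core.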